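A few compounds are considered here, and "the series" means these few. Any claim that something is new, unique, unknown or untested is made for them only; others in the source may bear on it.

Three measured compounds share one core and differ at a single place, the group on a carbonyl carbon: compound 1 `CCCCCC(=O)N[C@@H]1CCN(c2cc(C)nn3c(-c4ccc(OC)c(OC)c4)c(C)nc23)C1` with pentyl, compound 2 `COc1ccc(-c2c(C)nc3c(N4CC[C@@H](NC(=O)NC(C)C)C4)cc(C)nn23)cc1OC` with isopropylamino and compound 3 `COc1ccc(-c2c(C)nc3c(N4CC[C@@H](NC(=O)OCc5ccccc5)C4)cc(C)nn23)cc1OC` with benzyloxy. In an ADME assay on microsomes from liver (Homo sapiens) for metabolic stability, read by LC-MS, with NADPH named in the record, with a stated time of 60 min, tested at 1 uM, in the absence of a further agent (a lower number here means that less of the compound is left, a higher number that more of the compound is left), compound 3 gives > 95% as its reading, which is a limit of the assay and not a number. Compound 1 reads > 95% and that too is a limit. Compound 2 reads > 95% and that is also a limit. The whole picture is the limit of > 95% in this assay, at which 3 of the 3 values shown sit, and no finer ranking can be read from it.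

Compound 4 `COc1ccc(-c2c(C)nc3c(N4CC[C@@H](NS(C)(=O)=O)C4)cc(C)nn23)cc1OC` keeps the core and has methylsulfonyl in place of benzyloxycarbonyl on an amine nitrogen. The difference is methylsulfonyl in place of benzyloxycarbonyl on an amine nitrogen and nothing else changes.

Among the measured compounds shown here, no measured step makes this exact exchange. The nearest are a step that the two limits leave unreadable from compound 1 to compound 3 and a step that the two limits leave unreadable from compound 2 to compound 3 and neither has a readable size, yet pentyl, isopropylamino and benzyloxy all leave their compounds at the same limit. The estimated change is a number no higher from compound 3 to compound 4 (the limit leaves the size open) and no step beyond the usual scatter is expected, in either direction. Compound 4 is estimated at 95% with an expected range of 85% to 100% and it may well end at a limit again.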

Compound 4, percent of the compound remaining: > 95%
Compound 4: a limit, no number; the forecaster's own chance of this, stated with the estimate: 65%; the middle value lies on the limit itself.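

In this assay compound 4 gives > 95%, which is a limit of the assay and not a number. No step from compound 1, compound 2 or compound 3 to compound 4 can be read, because the compounds share one limit: the limit of > 95% in this assay, at which 4 of the 4 values shown sit.

These compounds leave open how far any of them truly differs from the others, and whether any group on the amine nitrogen matters here.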